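Swapping the Aryl Ring for a Pyridine in Compound 4

The source may hold more compounds than are shown below. What is called first, only, known or untested is meant among the compounds shown, and "the series" means these compounds.

Compound 1 `COc1cc(F)ccc1-c1cc2c(cn1)ncn2-c1ccc(OC(F)F)cc1` has the lowest number of the three measured compounds in a functional assay on HL-60 cells (Homo sapiens) for activation, read by flow cytometry, with a stated time of 4 days (on this read-out higher numbers stand for an effect only at larger amounts of compound and lower numbers for an effect already at smaller amounts), giving 93 nM. Compound 2 `Fc1ccc(-c2cc3c(cn2)ncn3-c2ccc(OC(F)F)cc2)c(C(F)(F)F)c1` gives 1500 nM and compound 3 `CC(C)Oc1cc(F)ccc1-c1cc2c(cn1)ncn2-c1ccc(OC(F)F)cc1` gives 1100 nM. Both steps away from compound 1 were large: a 16-fold higher number from compound 1 to compound 2 (1.21 log units; beyond the scatter) and a 12-fold higher number from compound 1 to compound 3 (1.07 log units; beyond the scatter). Compound 4 `Cc1cc(F)ncc1-c1cc2c(cn1)ncn2-c1ccc(OC(F)F)cc1` differs from compound 1 in one place: a group of 8 heavy atoms (6 carbon, 1 nitrogen, 1 fluorine; one six-membered aromatic ring with 1 hetero atom) in place of a group of 9 heavy atoms (7 carbon, 1 oxygen, 1 fluorine; one six-membered aromatic ring of carbon only), on an aromatic carbon. For the measured compounds named here, no measured step makes this exact exchange, but the two steps that alter the same ring both raised the number sharply, so an increase in this assay is expected, though of uncertain size since the whole ring is exchanged. Compound 4 is therefore estimated at 400 nM, within 80 nM to 2000 nM, meaning a 4.3-fold higher number from compound 1 to compound 4 (0.63 log units; beyond the scatter).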

Compound 4, half-maximal effective concentration: 1200 nM
The estimate for compound 4 lay 3.0-fold (0.48 log units) below the measured number; low and high end bracket the measured number.
By their numbers in this assay, from the lowest: compound 1; then compounds 3, 4 and 2 (each within the scatter of the next).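

Replacing the 4-fluoro-2-methoxyphenyl with a six-membered aromatic ring holding one hetero atom gives a 13-fold higher number from compound 1 to compound 4 (1.11 log units; beyond the scatter) in this assay. Exchanging the whole ring therefore also produces a large step at this position, as the two single-group changes did, and compound 1 still stands alone with the lowest number. Nothing available explains this rise. Still open, as far as these compounds go, is whether the ring nitrogen or the altered ring substituents account for the step, and whether ethoxy or an amine in place of methoxy would keep the number of compound 1.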